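The compounds below may be only part of what the source reports. "The series", "measured", "known", "first", "only" and "open" are said of these compounds alone.

In a functional assay on RAW264.7 cells (Mus musculus) for inhibition, read by Griess assay, with stated times of 1 h and 24 h (on this read-out higher numbers stand for weaker inhibition and lower numbers for stronger inhibition), compound 3 `CCCOc1ccccc1C1CC(=O)c2ccccc2O1` gives 46000 nM. Going by the values given here, that number sits at the upper end of the three measured so far, yet all three lie within the scatter of one another: compound 1 `C=CCOc1ccccc1C1CC(=O)c2ccccc2O1` gives 37800 nM and compound 2 `COCOc1ccccc1C1CC(=O)c2ccccc2O1` gives 32600 nM. Compound 4 `COc1ccccc1C1CC(=O)c2ccccc2O1` differs from compound 3 by hydrogen in place of ethyl on a saturated chain carbon bound to an oxygen on an aromatic ring. Among the compounds with values here, the steps that bear on this place are a 1.2-fold higher number from compound 1 to compound 3 (0.09 log units; within the scatter) and a 1.4-fold higher number from compound 2 to compound 3 (0.15 log units; within the scatter), and a 1.2-fold lower number from compound 1 to compound 2 (0.06 log units; within the scatter) likewise stays within the scatter. Three different groups at this place have given numbers the assay cannot tell apart, so the step expected here is a 1.2-fold lower number from compound 3 to compound 4 (0.06 log units; within the scatter), nothing beyond the scatter. Compound 4 is therefore estimated to give 40000 nM, with a range from 20000 nM to 80000 nM.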

Compound 4, half-maximal inhibitory concentration: 47300 nM
For compound 4 the middle estimate is 1.2-fold (0.07 log units) below the measured one; measured number inside the range.
By their numbers in this assay, from the lowest: compounds 2, 1, 3 and 4 (each within the scatter of the next).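

Trimming the propoxy of compound 3 down to a methoxy leaves the number where it was (a 1.0-fold higher number from compound 3 to compound 4 (0.01 log units; within the scatter)). The comparisons with the other two groups also stay within the scatter (a 1.5-fold higher number from compound 2 to compound 4 (0.16 log units; within the scatter); a 1.3-fold higher number from compound 1 to compound 4 (0.10 log units; within the scatter)). So the ethyl, the vinyl and the methoxy on this chain carbon can all give way to hydrogen with no change that this assay can detect, and no measured evidence offers an explanation for this. From the compounds shown here alone, whether an amine, a carboxylic acid or a much longer chain here would move the number beyond the scatter remains open.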